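Extending the Chain on a Trifluoromethyl Ketone Hydrate

The source may hold more compounds than are shown below. What is called first, only, known or untested is meant among the compounds shown, and "the series" means these compounds.

Of the compounds shown here, three have been measured in an assay on isolated protein for inhibition of liver carboxylesterase 1 (Homo sapiens), with a stated time of 24 h; on this read-out higher numbers stand for weaker inhibition and lower numbers for stronger inhibition. Compound 1, `CCCCCC[S+]([O-])CC(O)(O)C(F)(F)F`, gives 3.31 nM. Compound 2, `O=C(CSCCc1ccccc1)C(F)(F)F`, gives 6.46 nM, which sits within the scatter of compound 1. Compound 3, `CCCCCCCCCCCCS(=O)(=O)CC(O)(O)C(F)(F)F`, gives 0.398 nM, a lower number than compound 1 by a margin beyond the scatter. On these three numbers compound 1 stands second highest, close to compound 2 and far from compound 3.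

Compound 4, `CCCCCCCCCC[S+]([O-])CC(O)(O)C(F)(F)F`, is not yet measured. It differs from compound 1 in one place: butyl in place of hydrogen on a saturated chain carbon, six bonds along the chain from a sulfur. Compound 3 also carries a longer chain than compound 1 and gives the lowest number of the three, but it differs from compound 1 in more than the chain, so no single step can be read from that pair.

Given that compound 3 gives 0.398 nM with a longer chain, the step from compound 1 to compound 4 is expected to run downward, toward stronger inhibition, by a modest amount, a 2.8-fold lower number from compound 1 to compound 4 (0.44 log units; beyond the scatter). Compound 4 is therefore expected to give about 1.2 nM, with a range from 0.4 nM to 3.5 nM.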

Compound 4, inhibition constant: 0.501 nM
Compound 4: the middle estimate sits 2.4-fold (0.38 log units) above what was measured, within the range that was stated.
By their numbers in this assay, from the lowest: compounds 3 and 4 (each within the scatter of the next); then compounds 1 and 2 (each within the scatter of the next).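

Going by these compounds alone, this is the first change in the set that can be read on its own: in this assay, butyl in place of hydrogen on a saturated chain carbon, six bonds along the chain from a sulfur, gives a 6.6-fold lower number from compound 1 to compound 4 (0.82 log units; beyond the scatter). With the core of compound 1 left unchanged, the added butyl alone goes with stronger inhibition, and the shift is larger than repeat measurements would normally produce. Nothing measured here bears on why the number falls.

Two chain lengths on this core give a single step, which is not yet a trend, so they do not show whether the number would keep falling with a longer chain such as tetradecyl or would level off instead. Nor do they show how a chain carrying an amine or a carboxylic acid would read in this assay, so it remains open whether this position accepts only plain carbon chains or other groups as well.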